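Adding one carbon: from propyl to butyl

A few compounds are considered here, and "the series" means these few. Any claim that something is new, unique, unknown or untested is made for them only; others in the source may bear on it.

Measured in a functional assay on SK-BR-3 cells (Homo sapiens) for antiproliferative activity, read by MTT assay, with a stated time of 72 h; a lower number here means a stronger inhibitor, a higher number a weaker inhibitor:
- compound 1 `C/C=C1/[C@H](O[C@@H]2O[C@H](COC(C)=O)[C@@H](OC(C)=O)[C@H](OC(C)=O)[C@H]2OC(C)=O)OC=C(C(=O)OC)[C@H]1CC(=O)SCCc1ccccc1` gives > 15000 nM (a limit, not a number)
- compound 2 `C/C=C1/[C@H](O[C@@H]2O[C@H](COC(C)=O)[C@@H](OC(C)=O)[C@H](OC(C)=O)[C@H]2OC(C)=O)OC=C(C(=O)OC)[C@H]1CC(=O)OCC` gives > 15000 nM (a limit, not a number)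
- compound 3 `C/C=C1/[C@H](O[C@@H]2O[C@H](COC(C)=O)[C@@H](OC(C)=O)[C@H](OC(C)=O)[C@H]2OC(C)=O)OC=C(C(=O)OC)[C@H]1CC(=O)OCCC` gives 6600 nM

Compound 1 and compound 2 both stop at the limit of > 15000 nM in this assay, at which 2 of the 3 values shown sit. Going by the values given here, compound 3 is the only one with a true number, 6600 nM, so it is the sole firm reference point for what comes next.

The next compound is compound 4 `C/C=C1/[C@H](O[C@@H]2O[C@H](COC(C)=O)[C@@H](OC(C)=O)[C@H](OC(C)=O)[C@H]2OC(C)=O)OC=C(C(=O)OC)[C@H]1CC(=O)OCCCC`. It differs from compound 3 as follows: methyl in place of hydrogen on a saturated chain carbon, three bonds along the chain from an oxygen next to a carbonyl group. In plain terms, the chain grows from propyl to butyl.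

The nearest guide is an at least 2.2-fold lower number from compound 2 to compound 3 (0.35 log units; beyond the scatter). That step was the same kind of change, methyl in place of hydrogen, but two bonds along the chain from an oxygen next to a carbonyl group. Its true size stays hidden behind a limit. The other readable step, an at least 2.2-fold lower number from compound 1 to compound 3 (0.35 log units; beyond the scatter), swaps propoxy for phenethylsulfanyl and so says less about this change.

One step makes no trend, but a further modest fall in the number is expected in this assay, and the change could still stay within the scatter. The expected change is a 1.7-fold lower number from compound 3 to compound 4 (0.22 log units; within the scatter). The estimate for compound 4 is 4000 nM, with an expected range of 1500 nM to 11000 nM.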

Compound 4, half-maximal inhibitory concentration: > 15000 nM
Compound 4 ended at the assay's limit; the forecaster's own chance of this, stated with the estimate: 15%; middle value at least 3.7-fold (0.57 log units) from the limit.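

In this assay, adding one carbon to the chain does not keep lowering the number. Going from ethoxy to propoxy gave an at least 2.2-fold lower number from compound 2 to compound 3 (0.35 log units; beyond the scatter), whereas going from propyl to butyl reverses that direction and gives an at least 2.2-fold higher number from compound 3 to compound 4 (0.35 log units; beyond the scatter). Among the ethoxy, propoxy and butoxy compounds, only the propoxy compound 3 has a true number, so a chain one carbon shorter and a chain one carbon longer both end at the same limit: the limit of > 15000 nM in this assay, at which 3 of the 4 values shown sit.

From the compounds shown here alone, the steps from compound 1 and compound 2 to compound 4 cannot be read, as each joins two limits, so the order of these three compounds stays unknown. Going by these compounds, it also remains open whether a longer chain such as pentyl, a branched chain such as isopropyl, or an amine at the end of the propyl chain would bring the number below that of compound 3, or whether the propyl chain marks a real optimum at this position.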